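This account rests on a few compounds, and the source may have more. Where it says the series, first, only, none or still open, it means among the compounds named here.

In a functional assay on CHO cells for antagonist activity at transient receptor potential cation channel subfamily V member 1 (Rattus norvegicus), read by fluorescence, with a stated time of 1 h (a higher number here means a weaker inhibitor, a lower number a stronger inhibitor), compound 1 `CC(C(=O)NCc1ccc(C(C)(C)C)cc1)c1ccc(NS(C)(=O)=O)c(Br)c1` gives 25 nM, and compound 2 `CC(C(=O)NCc1ccc(C(C)(C)C)cc1)c1ccc(NS(C)(=O)=O)c(I)c1` gives 30 nM; the step of a 1.2-fold higher number from compound 1 to compound 2 (0.08 log units; within the scatter) lies within the scatter. For the measured compounds named here, compound 2 thus holds the higher of the two numbers so far, with compound 1 close beside it. Compound 3 `Cc1cc(C(C)C(=O)NCc2ccc(C(C)(C)C)cc2)ccc1NS(C)(=O)=O` differs from compound 2 by methyl in place of iodo on an aromatic carbon. Going by the values given here, only one measured step bears on this change, and it was within the scatter, so a modest shift is expected, if anything toward a higher number. The expected step of a 2.0-fold higher number from compound 2 to compound 3 (0.30 log units; within the scatter) is therefore small. Compound 3 is estimated at 60 nM, in a range from 20 nM to 200 nM.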

Compound 3, inhibition constant: 18.9 nM
Estimate against measurement, compound 3: 3.2-fold (0.50 log units) above, and the stated range ends above it.
By their numbers in this assay, from the lowest: compounds 3, 1 and 2 (each within the scatter of the next).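

Methyl in place of iodo gives a 1.6-fold lower number from compound 2 to compound 3 (0.20 log units; within the scatter) and methyl in place of bromo gives a 1.3-fold lower number from compound 1 to compound 3 (0.12 log units; within the scatter) so the earlier match between two halogens now extends to a carbon group. On this aromatic carbon, ortho to the methanesulfonamido group, the number therefore stays within the scatter across iodo, bromo and methyl. Nothing measured here explains why these three groups give such similar numbers. The compounds shown leave open how this position responds to a different kind of group, such as an amine, a carboxylic acid or a longer chain.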